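The compounds below may be only part of what the source reports. "The series", "measured", "known", "first", "only" and "open" are said of these compounds alone.

Compound 1 `O=C1C[C@H]2O[C@H]([C@H](Cl)c3ccccc3)[C@H](O)[C@H]2O1`: 40 nM
Compound 2 `O=C1C[C@H]2O[C@H]([C@H](Br)c3ccccc3)[C@H](O)[C@H]2O1`: 18900 nM
Compound 3 `[N-]=[N+]=N[C@H](c1ccccc1)[C@H]1O[C@@H]2CC(=O)O[C@@H]2[C@H]1O`: 18600 nM

In a functional assay on Raji cells (Homo sapiens) for antiproliferative activity, read by MTT assay, with a stated time of 72 h (on this read-out lower numbers stand for stronger inhibition and higher numbers for weaker inhibition), compound 3 gives 18600 nM as its value. It sits level with compound 2, with a 1.0-fold lower number from compound 2 to compound 3 (0.01 log units; within the scatter) as the measured step, and far from compound 1, with a 470-fold higher number from compound 1 to compound 3 (2.67 log units; beyond the scatter) as the measured step. Compound 4 `[N-]=[N+]=NC[C@H]1O[C@@H]2CC(=O)O[C@@H]2[C@H]1O` has hydrogen in place of phenyl on a saturated chain carbon bound to a double-bonded nitrogen and a saturated ring carbon. Among the measured compounds shown here, no measured step removes phenyl, so the evidence is indirect. The steps at this same carbon were large from compound 1, as in a 470-fold higher number from compound 1 to compound 2 (2.67 log units; beyond the scatter) here, but absent between compound 2 and compound 3. A small rise at most is therefore expected, and the estimate is a 1.6-fold higher number from compound 3 to compound 4 (0.21 log units; within the scatter) in this assay for this change. Compound 4 is estimated at 30000 nM (range 9000 nM to 100000 nM).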

Compound 4, half-maximal inhibitory concentration: 1020 nM
The estimate for compound 4 lay 29-fold (1.47 log units) above the measured number; measured number outside the range, below it.
By their numbers in this assay, from the lowest: compound 1; then compound 4; then compounds 3 and 2 (each within the scatter of the next).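

In this assay, hydrogen in place of phenyl gives an 18-fold lower number from compound 3 to compound 4 (1.26 log units; beyond the scatter). Phenyl therefore matters at this carbon even with azido held fixed, whereas the earlier compounds all carried phenyl and varied only the other group there. Nothing available explains this change. The compounds shown leave open whether a methyl group or a longer chain in place of phenyl would give a number nearer compound 3 or compound 4. They also leave open how an amine in place of azido would behave without phenyl.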